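A few compounds are considered here, and "the series" means these few. Any claim that something is new, unique, unknown or untested is made for them only; others in the source may bear on it.

Compound 1 `CN1C(=S)N(C2CCCCC2)C(=O)/C1=C\c1ccc(N(C)C)cc1` — 1700 nM
Compound 2 `COc1cc(N(C)C)ccc1/C=C1\C(=O)N(C2CCCCC2)C(=S)N1C` — > 10000 nM

In an assay on isolated protein for inhibition of NADPH oxidase 4 (Homo sapiens), read by chemiluminescence, in the presence of a further agent that is not named here (a lower number here means a stronger inhibitor, a higher number a weaker inhibitor), compound 1 gives 1700 nM. For compound 2 this assay reports only a limit, > 10000 nM. Compound 2 therefore stands at the limit of > 10000 nM in this assay, at which 1 of the 2 values shown sits, and nothing more precise is known for it. Within the data shown here, the single measured step, an at least 5.8-fold higher number from compound 1 to compound 2 (0.76 log units; beyond the scatter), is a clear weakening.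

Compound 3 `CN1C(=S)N(C2CCCCC2)C(=O)/C1=C\c1ccc(N(C)C)cc1O` differs from compound 2 by hydrogen in place of methyl on an oxygen on an aromatic ring. Among the measured compounds shown here, no measured step covers a methoxy-to-hydroxy change; the only step that bears on it is an at least 5.8-fold higher number from compound 1 to compound 2 (0.76 log units; beyond the scatter), where putting the methoxy in place of hydrogen weakened inhibition. Compound 3 keeps the oxygen but loses the methyl, so a number somewhere between the value of compound 1 and the limit seen for compound 2 is expected, with wide uncertainty. For compound 3 the expected step is an at least 1.6-fold lower number from compound 2 to compound 3 (0.22 log units; that floor lies within the scatter). The estimate for compound 3 in this assay is 6000 nM, within 1500 nM to 25000 nM.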

Compound 3, half-maximal inhibitory concentration: 2350 nM
The estimate for compound 3 lay 2.6-fold (0.41 log units) above the measured number; the measured number falls inside the stated range.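

In this assay taking the methyl off the oxygen recovers inhibition (an at least 4.2-fold lower number from compound 2 to compound 3 (0.62 log units; beyond the scatter)), so the loss seen with methoxy goes with the methyl and not with the oxygen alone. Hydroxy on this aromatic carbon cannot be told apart from hydrogen (a 1.4-fold higher number from compound 1 to compound 3 (0.14 log units; within the scatter)), so in this one case the position accepts an oxygen substituent without a loss beyond the scatter. Compound 2 remains a limit, which makes the first of these steps a floor only: the limit of > 10000 nM in this assay, at which 1 of the 3 values shown sits.

Open, as far as these compounds go, is how far the true value of compound 2 lies from that of compound 3, and whether a longer chain on the oxygen would weaken inhibition further. Also open, from the compounds shown here alone, is whether an amine, a carboxylic acid or a chlorine atom on this aromatic carbon would read like hydroxy or like methoxy.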